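A few compounds are considered here, and "the series" means these few. Any claim that something is new, unique, unknown or untested is made for them only; others in the source may bear on it.

Going by the values given here, compound 1 `COc1cc(NC(C)CCCNC(=O)Oc2ccc(Cl)cc2)c2ncccc2c1` shows the higher of the two numbers so far: in an ADME assay on liver (Rattus norvegicus) for activation, read by HPLC (on this read-out lower numbers stand for a shorter-lived compound and higher numbers for a longer-lived compound), compound 1 gives 11.8 h, while compound 2 `COc1cc(NC(C)CCCNC(=O)Oc2ccccc2)c2ncccc2c1` gives 9.5 h, and the step of a 1.2-fold lower number from compound 1 to compound 2 (0.09 log units; within the scatter) stays within the scatter. Compound 3 `CCCCCCOC(=O)NCCCC(C)Nc1cc(OC)cc2cccnc12` differs from compound 1 by hexyl in place of 4-chlorophenyl on an oxygen next to a carbonyl group. Among the compounds with values here, the only measured step concerns a chloro against hydrogen and gives no guide to exchanging a ring for a chain, so no direction can be drawn from it. Compound 3 is therefore expected near compound 1, as a 1.3-fold lower number from compound 1 to compound 3 (0.12 log units; within the scatter), with an estimate of 9 h between 3 h and 27 h.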

Compound 3, half-life: 10.4 h
Compound 3: the middle estimate sits 1.2-fold (0.06 log units) below what was measured; the measured number falls inside the stated range.
By their numbers in this assay, from the lowest: compounds 2, 3 and 1 (each within the scatter of the next).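

At this position, on an oxygen next to a carbonyl group, an open chain serves as well as an aromatic ring in this assay: hexyl in place of 4-chlorophenyl gives a 1.1-fold lower number from compound 1 to compound 3 (0.05 log units; within the scatter), and hexyl in place of phenyl gives a 1.1-fold higher number from compound 2 to compound 3 (0.04 log units; within the scatter). The read-out therefore separates neither ring from chain nor, among these compounds, chloro from hydrogen. No outside evidence bears on this result. The compounds shown leave open whether a shorter chain, or an amine or carboxylic acid at the end of the hexyl, would give a number beyond the scatter.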